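The source may hold more compounds than are shown below. What is called first, only, known or untested is meant among the compounds shown, and "the series" means these compounds.

Working notes on the series. Compound 1 `O=C(Nc1ccc(Cl)cc1)c1c(NC(=O)C(F)(F)F)sc2c1CCCCC2`, compound 2 `O=C(Nc1ccccc1)c1c(NC(=O)C(F)(F)F)sc2c1CCCCC2` and compound 3 `N#Cc1ccc(NC(=O)c2c(NC(=O)C(F)(F)F)sc3c2CCCCC3)cc1` share one core and differ only in the group carried on an aromatic carbon of a six-membered aromatic ring of carbon only. In an ADME assay on THP-1 cells (Homo sapiens) for cytotoxicity (on this read-out lower numbers stand for higher toxicity in this test and higher numbers for lower toxicity in this test), compound 1 gives only a limit of the assay, > 50000 nM, and not a number. Compound 2 likewise reaches only a limit in this assay, > 50000 nM. Within the data shown here, compound 3 is the single compound with a read number in this assay, 9110 nM. The two other values sit at the boundary of what the assay reads (the limit of > 50000 nM in this assay, at which 2 of the 3 values shown sit). The step between the two limits is not readable: a step that the two limits leave unreadable from compound 1 to compound 2. The two readable steps both end at compound 3: an at least 5.4-fold lower number from compound 1 to compound 3 (0.73 log units; beyond the scatter) and an at least 5.4-fold lower number from compound 2 to compound 3 (0.73 log units; beyond the scatter).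

Compound 4 `O=C(Nc1ccc(OC(F)(F)F)cc1)c1c(NC(=O)C(F)(F)F)sc2c1CCCCC2` is not yet measured in this assay. The change is trifluoromethoxy in place of cyano on an aromatic carbon. Both readable steps show that the cyano group is the one that goes with the lower number, so taking it away is expected to move the number back toward the limit shared by compound 1 and compound 2. Compound 4 is therefore expected to give about 40000 nM in this assay, within 12000 nM to 100000 nM. The expected step is a 4.4-fold higher number from compound 3 to compound 4 (0.64 log units; beyond the scatter), and the result may well be returned as a limit rather than a number.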

Compound 4, half-maximal cytotoxic concentration: 11900 nM
Estimate against measurement, compound 4: 3.4-fold (0.53 log units) above; measured number outside the range, below it.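

In this assay, among these compounds, the change from cyano to trifluoromethoxy gives a 1.3-fold higher number from compound 3 to compound 4 (0.12 log units; within the scatter) and so cyano is no longer the only group on this aromatic carbon that goes with a read number. Trifluoromethoxy also separates from the other two groups, with an at least 4.2-fold lower number from compound 2 to compound 4 (0.62 log units; beyond the scatter) against hydrogen and an at least 4.2-fold lower number from compound 1 to compound 4 (0.62 log units; beyond the scatter) against chloro. Both of these steps are open-ended, as compound 1 and compound 2 each stand at a limit and not at a number: the limit of > 50000 nM in this assay, at which 2 of the 4 values shown sit.

Still open, from the compounds shown here alone, is whether an amine or a carboxylic acid on this aromatic carbon would fall with cyano and trifluoromethoxy or with hydrogen and chloro. Going by these compounds, the step between compound 1 and compound 2 cannot be read, so any difference between chloro and hydrogen also stays open.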